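The source may report more compounds than this note shows. Statements on the series, on what has been measured and on what is new or still open speak of the compounds shown alone.

Three compounds share one core, and all three have been measured in a functional assay on COLO 205 cells (Homo sapiens) for inhibition, read by sulforhodamine B assay, with a stated time of 48 h; a higher number here means a weaker inhibitor of growth, a lower number a stronger inhibitor of growth. Compound 1 `COc1ccc(-c2cc(/C=C/C(=O)c3ccc(N)cc3)[nH]n2)cc1` gives 1850 nM. Compound 2 `COc1cc(-c2cc(/C=C/C(=O)c3ccc(N)cc3)[nH]n2)cc(OC)c1OC` gives 1740 nM, and compound 3 `COc1ccc(C(=O)/C=C/c2cc(-c3cc(OC)c(OC)c(OC)c3)n[nH]2)cc1OC` gives 1740 nM. On these numbers compound 2 sits level with compound 3, the two together holding the lowest numbers of the three, while compound 1 differs from compound 2 by a margin within the scatter. Among the measured compounds shown here, the single measured step between close neighbours, no change at the digits printed from compound 2 to compound 3 (within the scatter), replaced 4-aminophenyl with 3,4-dimethoxyphenyl on a carbonyl carbon.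

Compound 4 `COc1ccc(C(=O)/C=C/c2cc(-c3cc(OC)c(OC)c(OC)c3)n[nH]2)cc1` differs from compound 2 by methoxy in place of amino on an aromatic carbon. The step from compound 2 to compound 3 is the only measured one that bears on this change: it likewise swapped an amino-bearing ring for a methoxy-bearing one and left the number unmoved within the scatter. A step of similar size is therefore expected here, a 1.0-fold higher number from compound 2 to compound 4 (0.01 log units; within the scatter), meaning no shift beyond the scatter in this assay. Compound 4 is accordingly estimated at 1800 nM, with a range from 900 nM to 3600 nM.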

Compound 4, concentration for 50% growth inhibition: 1730 nM
The estimate for compound 4 lay 1.0-fold (0.02 log units) above the measured number, within the range that was stated.
By their numbers in this assay, from the lowest: compounds 4, 2, 3 and 1 (each within the scatter of the next).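

In this assay, the change from 4-aminophenyl to 4-methoxyphenyl gives a 1.0-fold lower number from compound 2 to compound 4 (0.00 log units; within the scatter), so at this ring carbon the amino group, with its hydrogen-bond donor, can give way to methoxy, which has none, without a shift beyond the scatter. Hydrogen in place of methoxy on the same ring gives a 1.0-fold lower number from compound 3 to compound 4 (0.00 log units; within the scatter), so the ring of compound 4 with its single methoxy and the 3,4-dimethoxyphenyl ring of compound 3 cannot be told apart in this assay. No measurement here offers an explanation for these flat results.

As far as these compounds go, whether a carboxylic acid, a fluorine atom or a longer chain such as butoxy on this ring would move the number beyond the scatter remains open. So does whether hydrogen alone at this ring carbon, with no amino or methoxy group, would leave the number in place.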